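Trading a chlorinated ring for a benzyl arm

The source may report more compounds than this note shows. Statements on the series, on what has been measured and on what is new or still open speak of the compounds shown alone.

Measured so far:
Compound 1 `O=c1c2ccccc2c(Cc2ccc(Cl)cc2)nn1CCNCCCCc1ccc(OCCCN2CCCCCC2)cc1` gives 316 nM in an assay for binding affinity to Alpha-1B adrenergic receptor (Homo sapiens); a higher number here means a weaker inhibitor, a lower number a stronger inhibitor.
Compound 2 `CN1CCC[C@@H]1Cn1nc(Cc2cccc(Cl)c2)c2ccccc2c1=O` gives 631 nM.
Compound 3 `CN1CCC[C@@H]1Cn1nc(Cc2ccc(C(C)(C)C)cc2)c2ccccc2c1=O` reaches only a limit, > 1990 nM, where the measurement stops instead of giving a number.

Of the two numbers recorded, compound 2 holds the higher one; its nearest neighbour, compound 1, sits lower, but the gap between the two lies within the usual scatter, so they cannot be told apart. The third value is the limit of > 1990 nM in this assay, at which 1 of the 3 values shown sits.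

Compound 4 `CN1CCC[C@@H]1Cn1nc(CCc2ccccc2)c2ccccc2c1=O` has not been measured. It differs from compound 2 in one place: benzyl in place of 3-chlorophenyl on a saturated chain carbon bound to an aromatic carbon. Going by the values given here, no measured pair in this set shows that change, so the size of the step can only be guessed. The expectation is a modest move toward a weaker binder, one that may not clear the scatter. Compound 4 is therefore expected to give about 1000 nM in this assay, somewhere between 400 nM and 2500 nM. The step this estimate implies, a 1.6-fold higher number from compound 2 to compound 4 (0.20 log units; within the scatter), is expected to be small.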

Compound 4, inhibition constant: 200 nM
For compound 4 the middle estimate is 5.0-fold (0.70 log units) above the measured one; the measured number lies below the stated range.
By their numbers in this assay, from the lowest: compounds 4, 1 and 2 (each within the scatter of the next, the first and the last beyond it). At a limit, above all of these: compound 3.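

In this assay, going by these compounds alone, this is the first single change at this position that can be read, and it gives a 3.2-fold lower number from compound 2 to compound 4 (0.50 log units; beyond the scatter). The 3-chlorobenzyl arm is therefore not needed for binding here, and phenethyl, which carries no chlorine and has a longer chain, gives a stronger binder. The compounds shown hold no measurement that explains this step.

Losing the chlorine and lengthening the chain happen together in this step, so the contribution of each remains unknown. A 3-chlorophenethyl arm would keep the longer chain with the chlorine in place and so help separate the two, while a 3-phenylpropyl arm would test whether lengthening the chain further continues the trend or reverses it.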